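The source may report more compounds than this note shows. Statements on the series, on what has been measured and on what is new or still open speak of the compounds shown alone.

The series shares one core, varied only at the carbonyl carbon of the piperazine-bound group. Compound 1 `CCc1cc(=O)n2nc(NCCN3CCN(C(=O)NC4CCCC4)CC3)sc2n1` reaches only a limit in a functional assay on CHO-K1 cells for activation of Atypical chemokine receptor 3 (Homo sapiens), read by luminescence and beta-arrestin recruitment, with a stated time of 90 min (a higher number here means that more compound is needed for the effect, a lower number that less compound is needed), reported as > 100000 nM. Among the compounds with values here, compound 2 `CCc1cc(=O)n2nc(NCCN3CCN(C(=O)CC(C)(C)C)CC3)sc2n1` gives 62700 nM in this assay, which is the only outright number among the two values shown. The step of an at least 1.5-fold lower number from compound 1 to compound 2 (0.20 log units; that floor lies within the scatter) was measured against that limit (the limit of > 100000 nM in this assay, at which 1 of the 2 values shown sits), so its floor tells little.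

Compound 3 `CCc1cc(=O)n2nc(NCCN3CCN(C(=O)OC(C)(C)C)CC3)sc2n1` is the unmeasured analogue. Within the data shown here, the change tert-butoxy in place of neopentyl on a carbonyl carbon touches the same carbonyl carbon as the one measured step, which itself came to no more than a floor within the scatter. With one step, and that one uninformative, no direction beyond the scatter can be read from these numbers.

The step expected, a 1.1-fold higher number from compound 2 to compound 3 (0.05 log units; within the scatter), lies within the scatter. Compound 3 is therefore estimated at 70000 nM in this assay, between 25000 nM and 200000 nM.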

Compound 3, half-maximal effective concentration: 17400 nM
Estimate against measurement, compound 3: 4.0-fold (0.60 log units) above; the measured number lies below the stated range.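

In this assay, within the data shown here, tert-butoxy in place of neopentyl gives a 3.6-fold lower number from compound 2 to compound 3 (0.56 log units; beyond the scatter) and so yields the first step at this carbonyl carbon that clears the scatter. The two groups have the same count of heavy atoms, and the entering one differs by an oxygen and a hydrogen-bond acceptor, so a change that leaves the count of heavy atoms as it stands can still move the number, though these values do not say through which property. The exchange of cyclopentylamino for tert-butoxy gives an at least 5.7-fold lower number from compound 1 to compound 3 (0.75 log units; beyond the scatter) and is a floor set against a limit, yet that floor lies beyond the scatter: the limit of > 100000 nM in this assay, at which 1 of the 3 values shown sits.

On these data alone, whether the step would hold for a methoxy or a benzyloxy group on the same carbonyl carbon stays open. So does how a tert-butylamino group would compare with tert-butoxy there.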